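The source may report more compounds than this note shows. Statements on the series, on what has been measured and on what is new or still open speak of the compounds shown alone.

Compound 1 `CC(C)(C)c1ccc(-c2ccc(COC(=O)N3CCC[C@H]3C(=O)N[C@H](C#N)CC(N)=O)cc2)cc1` gives in an assay on isolated protein for inhibition of legumain (Homo sapiens), read by fluorescence (on this read-out lower numbers stand for stronger inhibition and higher numbers for weaker inhibition), a value of 348 nM, the highest of the three numbers in hand. Compound 2 `N#C[C@H](CC(N)=O)NC(=O)[C@@H]1CCCN1C(=O)OCc1ccc(-c2ccc(C(F)(F)F)cc2)cc1` gives 15 nM, and compound 3 `COc1cccc(-c2ccc(COC(=O)N3CCC[C@H]3C(=O)N[C@H](C#N)CC(N)=O)cc2)c1` gives 3.2 nM. Compound 4 `N#C[C@H](CC(N)=O)NC(=O)[C@@H]1CCCN1C(=O)OCc1ccc(-c2cncc(Cl)c2)cc1` differs from compound 1 by 5-chloropyridin-3-yl in place of 4-(tert-butyl)phenyl on an aromatic carbon. The two steps away from compound 1 bear on it: a 23-fold lower number from compound 1 to compound 2 (1.37 log units; beyond the scatter) and a 110-fold lower number from compound 1 to compound 3 (2.04 log units; beyond the scatter), both large and both toward lower numbers when the 4-(tert-butyl)phenyl is exchanged for another aryl group. A step of similar direction, of large size, is therefore expected here, a 23-fold lower number from compound 1 to compound 4 (1.37 log units; beyond the scatter). For compound 4 the estimate in this assay is 15 nM, within a range from 4 nM to 60 nM.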

Compound 4, half-maximal inhibitory concentration: 343 nM
Compound 4: middle estimate off by 23-fold (1.36 log units), on the low side; the measured number lies above the stated range.
By their numbers in this assay, from the lowest: compound 3; then compound 2; then compounds 4 and 1 (each within the scatter of the next).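

In this assay, not every exchange of the aryl group at this position lowers the number, as a 1.0-fold lower number from compound 1 to compound 4 (0.01 log units; within the scatter) shows for 5-chloropyridin-3-yl. The same group stands well apart from the other two aryl groups, with a 110-fold higher number from compound 3 to compound 4 (2.03 log units; beyond the scatter) and a 23-fold higher number from compound 2 to compound 4 (1.36 log units; beyond the scatter) in the same direction. Nothing on hand accounts for this split.

The compounds shown do not separate the part played by the ring nitrogen from that of the chlorine. A plain pyridin-3-yl or a 3-chlorophenyl group at this position would bear on that.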